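This account rests on a few compounds, and the source may have more. Where it says the series, first, only, none or still open, it means among the compounds named here.

Three compounds have been measured in a functional assay on the whole organism with Mus musculus as the target; a higher number here means that more compound is needed for the effect, a lower number that less compound is needed:

compound 1, `CCCS(=O)(=O)N1CCN(C(=O)CC)CC1`, where compound 1 gives 1 mg/kg
compound 2, `CCCS(=O)(=O)N1CCN(C(C)=O)CC1`, where compound 2 gives 0.1 mg/kg
compound 3, `CC(=O)N1CCCN(S(=O)(=O)c2ccc(F)cc2)CC1`, where compound 3 gives 1 mg/kg

Compound 3 stands level with compound 1 at the digits shown, and the two together give the highest numbers of the three. Compound 2 sits furthest from compound 3, with the lowest number of the three.

Compound 4, `CCC(=O)N1CCCN(S(=O)(=O)c2ccc(F)cc2)CC1`, has not yet been measured in this assay. It differs from compound 3 by methyl in place of hydrogen on a saturated chain carbon bound to a carbonyl carbon. Going by the values given here, one measured step bears on this change: the same alteration in the opposite direction, on the core shared by compound 1 and compound 2, gave a 10-fold lower number from compound 1 to compound 2 (1.00 log units; beyond the scatter). Reversing that alteration is expected to raise the number, although the core of compound 3 is different and no step on that core has been measured, so the size is uncertain. Compound 4 is therefore expected to need more compound than compound 3, an estimated 3.0-fold higher number from compound 3 to compound 4 (0.48 log units; beyond the scatter). The estimate for compound 4 is 3 mg/kg, with a range from 1 mg/kg to 10 mg/kg.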

Compound 4, minimum effective dose: 1 mg/kg
Beside the measured number, compound 4's estimate is 3.0-fold (0.48 log units) above it; the range from low to high includes it.
By their numbers in this assay, from the lowest: compound 2; then compounds 1, 3 and 4 (each within the scatter of the next).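

In this assay, replacing acetyl with propanoyl on the core of compound 3 gave no change at the digits printed from compound 3 to compound 4 (within the scatter). The rise in the number that this added methyl brought on the core of compound 1 therefore does not carry over to the core of compound 3, so the outcome of this change depends on the core that carries it: the same change on two cores in this assay, a 10-fold lower number (1.00 log units; beyond the scatter) from compound 1 to compound 2 and no change at the digits printed (within the scatter) from compound 4 to compound 3, 10-fold (1.00 log units) apart, beyond the scatter of two such steps. On the core of compound 3, this saturated chain carbon bound to a carbonyl carbon accepts a methyl with no change beyond the scatter, although two cores are too few to support a general rule.

As far as these compounds go, it remains open whether a longer chain, such as butanoyl, or an amine on this chain would also leave the number unchanged on the core of compound 3. The two cores differ in more than one place, so which of those differences decides the outcome is also unresolved.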